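Styryl lactones and pyranones: growth inhibition notes

The source may report more compounds than this note shows. Statements on the series, on what has been measured and on what is new or still open speak of the compounds shown alone.

Measured compounds:
compound 1 `O=c1ccoc(/C=C/c2ccccc2)c1`, 691 uM
compound 2 `COc1ccc(/C=C/c2cc(=O)cco2)cc1`, 396 uM
compound 3 `COc1ccc(/C=C/C2CC=CC(=O)O2)cc1`, 25.5 uM

All three were measured in a functional assay on MCF7 cells (Homo sapiens) for inhibition, read by sulforhodamine B assay, with a stated time of 48 h; a lower number here means a stronger inhibitor of growth, a higher number a weaker inhibitor of growth. The change from compound 1 to compound 2 is methoxy in place of hydrogen on an aromatic carbon; it gave a 1.7-fold lower number from compound 1 to compound 2 (0.24 log units; within the scatter). The cores of compound 1 and compound 3 differ in more than one place, and that difference is not broken down here. Compound 4 `COc1ccc(/C=C/C2CC=CC(=O)O2)cc1OC` is not yet measured. It differs from compound 3 by methoxy in place of hydrogen on an aromatic carbon. This is the same kind of change as that from compound 1 to compound 2, but the place is not the same: in compound 2 the entering methoxy sits para to a group of 9 heavy atoms, whereas in compound 4 it sits ortho to a methoxy group and meta to a group of 9 heavy atoms.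

In this assay the step from compound 3 to compound 4 is expected to be a 1.4-fold lower number from compound 3 to compound 4 (0.15 log units; within the scatter), resting on the earlier step of the same kind, a 1.7-fold lower number from compound 1 to compound 2 (0.24 log units; within the scatter), which lay within the scatter. Compound 4 is therefore estimated at 18 uM, with a likely range from 6 uM to 55 uM.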

Compound 4, concentration for growth inhibition (reported as GI): 7.8 uM
Estimate against measurement, compound 4: 2.3-fold (0.36 log units) above, within the range that was stated.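

In this assay, methoxy in place of hydrogen on an aromatic carbon gives a 3.3-fold lower number from compound 3 to compound 4 (0.51 log units; beyond the scatter), a modest step. On these two cores, the two steps of this change do not differ beyond the scatter: the same change on two cores in this assay, a 1.7-fold lower number (0.24 log units; within the scatter) from compound 1 to compound 2 and a 3.3-fold lower number (0.51 log units; beyond the scatter) from compound 3 to compound 4, 1.9-fold (0.27 log units) apart, within the scatter of two such steps. Among the compounds shown here, this does not show that the step has a fixed size across the series, since it rests on only two pairs, the methoxy enters at a different place in each, and the earlier step alone lies within the scatter.

The compounds shown leave open how other groups at this place would compare, such as an amine, a carboxylic acid or a longer alkoxy chain. They also leave open whether the same substitution pattern would behave alike on the core of compound 1.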